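Propargyl for sec-butyl on a purine-like scaffold: cytotoxicity estimate

The source may hold more compounds than are shown below. What is called first, only, known or untested is meant among the compounds shown, and "the series" means these compounds.

Measured so far:
Compound 1, `COc1cc(Cc2nc3c(N)ncnc3n2CC(C)CCCO)cc(OC)c1OC`: 8770000 nM
Compound 2, `CC[C@H](C)Cn1c(Cc2cc(OC)c(OC)c(OC)c2)nc2c(N)nc(F)nc21`: 66700000 nM

In a functional assay on MCF7 cells (Homo sapiens) for cytotoxicity (a higher number here means that more compound is needed for the effect, a lower number that less compound is needed), compound 2 gives the higher of the two numbers; the number for compound 1 is lower, and that gap lies beyond the scatter. Compound 3, `C#CCCn1c(Cc2cc(OC)c(OC)c(OC)c2)nc2c(N)nc(F)nc21`, differs from compound 2 in one place: propargyl in place of sec-butyl on a saturated chain carbon bound to an aromatic nitrogen. Within the data shown here, no measured pair shows this exact change, so no firm size of step can be drawn from the data. The expected step from compound 2 to compound 3 is a 1.3-fold lower number from compound 2 to compound 3 (0.13 log units; within the scatter), a small shift likely within the scatter. Compound 3 is thus estimated at 50000000 nM, within 15000000 nM to 150000000 nM.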

Compound 3, half-maximal effective concentration: 286000000 nM
Compound 3: the middle estimate sits 5.7-fold (0.76 log units) below what was measured; measured number above the stated range.
By their numbers in this assay, from the lowest: compound 1; then compound 2; then compound 3.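

In this assay propargyl in place of sec-butyl on a saturated chain carbon bound to an aromatic nitrogen gives a 4.3-fold higher number from compound 2 to compound 3 (0.63 log units; beyond the scatter) and shows that the number responds to the group at this position. In this single pair, the triple-bonded chain calls for more compound than the sec-butyl group. Nothing available explains the size or direction of this step.

Going by these compounds, whether a chain ending in an amine or a carboxylic acid would lower the number at this position remains open. One pair also cannot show whether the step would carry over to another core.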